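Swapping a Chlorophenyl for a Chloropyrimidinyl on a Shared Core

The source may hold more compounds than are shown below. What is called first, only, known or untested is meant among the compounds shown, and "the series" means these compounds.

Compound 1 `Cn1c(C2CC2)nc2ccc(-n3ccc(OCc4cccc(Cl)c4)cc3=O)cc21` and compound 2 `Cn1c(C2CC2)nc2ccc(-n3ccc(OCc4ccccc4Cl)cc3=O)cc21` share one core and differ only in the chlorophenyl attached through the ether. In an assay on CHO cells for displacement of a labelled ligand from melanin-concentrating hormone receptor 1 (Rattus norvegicus), read by scintillation counting, with a stated time of 1 h (on this read-out lower numbers stand for stronger inhibition and higher numbers for weaker inhibition), compound 1 gives 72 nM, while compound 2 gives 140 nM. The step of a 1.9-fold higher number from compound 1 to compound 2 (0.29 log units; within the scatter) lies within the scatter, so compound 2 holds the highest of the two numbers without being separable from compound 1. Compound 3 `Cn1c(C2CC2)nc2ccc(-n3ccc(OCc4ncc(Cl)cn4)cc3=O)cc21` has not yet been measured. Its change from compound 2 is 5-chloropyrimidin-2-yl in place of 2-chlorophenyl on a saturated chain carbon bound to an oxygen on an aromatic ring. Within the data shown here, no measured step exchanges a ring of carbon only for a ring with two hetero atoms; the single known step, from compound 1 to compound 2, moved only a chlorine and stayed within the scatter. The expectation therefore rests on little, and a modest weakening is assumed. Compound 3 is expected at 250 nM, within 60 nM to 1000 nM, an expected step of a 1.8-fold higher number from compound 2 to compound 3 (0.25 log units; within the scatter).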

Compound 3, half-maximal inhibitory concentration: 900 nM
The estimate for compound 3 lay 3.6-fold (0.56 log units) below the measured number; low and high end bracket the measured number.
By their numbers in this assay, from the lowest: compounds 1 and 2 (each within the scatter of the next); then compound 3.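

In this assay, replacing the chlorophenyl ring with 5-chloropyrimidin-2-yl gives a 6.4-fold higher number from compound 2 to compound 3 (0.81 log units; beyond the scatter) and also a 13-fold higher number from compound 1 to compound 3 (1.10 log units; beyond the scatter) as steps that clearly exceed ordinary assay variation. Until now, this position had shown only a 1.9-fold higher number from compound 1 to compound 2 (0.29 log units; within the scatter) when 2-chlorophenyl took the place of 3-chlorophenyl, so the identity of the ring here can change the result more than that exchange did. Going from a ring of carbon only to a ring with 2 hetero atoms, with the heavy-atom count unchanged, moves the number upward, but nothing available explains the rise.

The compounds shown leave open whether a single ring nitrogen, as in a 5-chloropyridin-2-yl group, would produce a similar rise. They also leave open how the number would respond to a methoxy group in place of the chlorine on the pyrimidine ring.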